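This account rests on a few compounds, and the source may have more. Where it says the series, first, only, none or still open, it means among the compounds named here.

Two hydroxamic acids are in hand. In a functional assay on PC-3 cells (Homo sapiens) for inhibition (a lower number here means a stronger inhibitor, a higher number a weaker inhibitor), compound 1 `CN(O)C(=O)/C=C/C=C/c1ccccc1` gives 11800000 nM, and compound 2 `O=C(CCCCc1ccccc1)NO` gives 23800000 nM. Compound 2 shows the higher of the two numbers, but the gap to compound 1 lies within the scatter, so the two read as equivalent. Compound 3 `O=C(CCCCCc1ccccc1)NO` differs from compound 2 by (hydroxycarbamoyl)methyl in place of hydroxycarbamoyl on a saturated chain carbon, four bonds along the chain from an aromatic carbon. Going by the values given here, no measured pair shows this chain lengthening, so no step beyond the scatter is expected in this assay; the expected step of a 1.2-fold lower number from compound 2 to compound 3 (0.08 log units; within the scatter) is small. Compound 3 is estimated at 20000000 nM, with a range from 8000000 nM to 50000000 nM.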

Compound 3, half-maximal inhibitory concentration: 83300000 nM
Compound 3: middle estimate off by 4.2-fold (0.62 log units), on the low side; the measured number lies above the stated range.
By their numbers in this assay, from the lowest: compounds 1 and 2 (each within the scatter of the next); then compound 3.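

This position is not silent: in this assay, (hydroxycarbamoyl)methyl in place of hydroxycarbamoyl on a saturated chain carbon, four bonds along the chain from an aromatic carbon, gives a 3.5-fold higher number from compound 2 to compound 3 (0.54 log units; beyond the scatter) and so marks a weaker inhibitor. Going by these compounds alone, this is the only step available, and it rests on one pair. Nothing at hand accounts for the loss.

Still open, on these data alone, is whether a longer chain would weaken inhibition further. Also open, as far as these compounds go, is how a carboxylic acid or an amine would read in place of the hydroxycarbamoyl group.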